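Dichlorophenyl swap from compound 2 to compound 4

The source may hold more compounds than are shown below. What is called first, only, known or untested is meant among the compounds shown, and "the series" means these compounds.

In a functional assay on SK-OV-3 cells (Homo sapiens) (a higher number here means a weaker inhibitor of growth, a lower number a stronger inhibitor of growth), compound 1 (`O=S(=O)(/C=C/c1ccccc1)Cc1ccc(Nc2ncnc3ccccc23)cc1`) gives 5000 nM, compound 3 (`CC(C)(C)c1cc(/C=C/S(=O)(=O)Cc2ccc(Nc3ncnc4ccccc34)cc2)cc(C(C)(C)C)c1O`) gives 3000 nM and compound 2 (`O=S(=O)(/C=C/c1ccc(Cl)c(Cl)c1)Cc1ccc(Nc2ncnc3ccccc23)cc1`) gives 22000 nM, the highest number of the three. Compound 4 (`O=S(=O)(/C=C/c1ccc(Cl)cc1Cl)Cc1ccc(Nc2ncnc3ccccc23)cc1`) differs from compound 2 in one place: 2,4-dichlorophenyl in place of 3,4-dichlorophenyl on a double-bonded chain carbon bound to a double-bonded chain carbon. Among the measured compounds shown here, the only measured step bearing on this change is a 4.4-fold higher number from compound 1 to compound 2 (0.64 log units; beyond the scatter), modest and beyond the scatter, for 3,4-dichlorophenyl in place of phenyl. For the measured compounds named here, no measured compound carries 2,4-dichlorophenyl, so that step serves only as a rough upper guide to size. A small step toward a lower number is expected, a 1.7-fold lower number from compound 2 to compound 4 (0.23 log units; within the scatter). For compound 4 the estimated value is 13000 nM, with an expected range of 4500 nM to 32000 nM.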

Compound 4, concentration for 50% growth inhibition: 2000 nM
Beside the measured number, compound 4's estimate is 6.5-fold (0.81 log units) above it; the whole stated range lies above it.
By their numbers in this assay, from the lowest: compounds 4, 3 and 1 (each within the scatter of the next, the first and the last beyond it); then compound 2.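

In this assay the arrangement of the chlorines on this phenyl, not their mere presence, decides the outcome: with the same atoms, 2,4-dichlorophenyl in place of 3,4-dichlorophenyl gives an 11-fold lower number from compound 2 to compound 4 (1.04 log units; beyond the scatter) as a large step. Against plain phenyl, 2,4-dichlorophenyl gives a 2.5-fold lower number from compound 1 to compound 4 (0.40 log units; beyond the scatter) as a modest step, opposite in direction to a 4.4-fold higher number from compound 1 to compound 2 (0.64 log units; beyond the scatter) for 3,4-dichlorophenyl. Dichlorophenyl at this place can therefore move the number either way. From the compounds shown here alone, whether a single chlorine or a methoxy group on this phenyl would follow compound 4 or compound 2 stays open. Nothing at hand accounts for the gap between the two chlorine patterns.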